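This account rests on a few compounds, and the source may have more. Where it says the series, first, only, none or still open, it means among the compounds named here.

Values in an ADME assay on MT4 cells (Homo sapiens) for cytotoxicity, read by MTT assay, with a stated time of 5 days (a higher number here means that more compound is tolerated, a lower number that less compound is tolerated), for the measured compounds:

compound 1 `CCOC(=O)Cn1cc(CNC(=O)c2cnc(Nc3ccc(C#N)cc3)cc2Oc2c(C)cc(C)cc2C)nn1`: 9530 nM
compound 2 `Cc1cc(C)c(Oc2cc(Nc3ccc(C#N)cc3)ncc2C(=O)NCc2cn(Cc3ccccc3Cl)nn2)c(C)c1`: >= 188000 nM, a limit of the assay
compound 3 `Cc1cc(C)c(Oc2cc(Nc3ccc(C#N)cc3)ncc2C(=O)NCc2cn(Cc3ccc(F)cc3)nn2)c(C)c1`: >= 153000 nM, a limit of the assay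

Going by the values given here, compound 1 holds the only number in this assay; the other two values shown are limits. Compound 2 sits at the limit of >= 188000 nM in this assay, at which 1 of the 3 values shown sits. Compound 3 sits at the limit of >= 153000 nM in this assay, at which 1 of the 3 values shown sits. The steps from compound 1 are an at least 19-fold higher number from compound 1 to compound 2 (1.29 log units; beyond the scatter) and an at least 16-fold higher number from compound 1 to compound 3 (1.20 log units; beyond the scatter). Between compound 2 and compound 3 the two limits leave a step that the two limits leave unreadable from compound 2 to compound 3.

Compound 4 `Cc1cc(C)c(Oc2cc(Nc3ccc(C#N)cc3)ncc2C(=O)NCc2cn(CC(=O)N3CCCC3)nn2)c(C)c1` differs from compound 1 in pyrrolidin-1-yl in place of ethoxy on a carbonyl carbon. The measured steps both remove the ethoxycarbonyl altogether and put in an aryl group, so they bear on compound 4 only loosely; the carbonyl is kept here. Given that both measured steps away from compound 1 in this assay gave large rises, compound 4 is expected to show a smaller rise estimated as a 3.1-fold higher number from compound 1 to compound 4 (0.50 log units; beyond the scatter). Compound 4 is expected at 30000 nM, estimated between 8000 nM and 150000 nM.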

Compound 4, half-maximal cytotoxic concentration: 58100 nM
Compound 4: the middle estimate sits 1.9-fold (0.29 log units) below what was measured, within the range that was stated.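

In this assay, a change confined to the group on the carbonyl carbon is enough to shift the read-out: a 6.1-fold higher number from compound 1 to compound 4 (0.79 log units; beyond the scatter). Going by these compounds alone, the ethoxycarbonyl therefore need not be removed altogether for more compound to be tolerated, as the earlier steps to aryl groups could not show. On these data alone, the carbonyl-bearing compound 4 still stays under both aryl compounds, an at least 2.6-fold lower number from compound 3 to compound 4 (0.42 log units; beyond the scatter) and an at least 3.2-fold lower number from compound 2 to compound 4 (0.50 log units; beyond the scatter), though both steps start from limits of the assay and not from numbers, so their full size is unknown.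

The compounds shown do not separate the effect of the ethoxy leaving from that of the pyrrolidin-1-yl ring entering. Dimethylamino or morpholin-4-yl on the same carbonyl carbon, or a carboxylic acid in place of the ester, would help to tell these apart.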